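A few compounds are considered here, and "the series" means these few. Any claim that something is new, unique, unknown or untested is made for them only; others in the source may bear on it.

Values in a functional assay on MONO-MAC-6 cells (Homo sapiens) for cytotoxicity, read by MTT assay, with a stated time of 24 h (on this read-out higher numbers stand for weaker inhibition and lower numbers for stronger inhibition), follow
- compound 1 `O=C(Nc1ccc(C(F)(F)F)cc1)c1cc(Cl)ccc1O` gives 2200 nM
- compound 2 `C/C(=N\OCC(=O)N[C@H](C(=O)O)[C@@H](C)O)c1ccc(NC(=O)c2cc(Br)ccc2O)cc1` gives > 200000 nM as a limit of the assay

Within the data shown here, compound 1 is the only exact number so far, and the other reading is a limit. Compound 3 `O=C(Nc1ccc(C(F)(F)F)cc1)c1cc(Br)ccc1O` differs from compound 1 in one place, where bromo in place of chloro on an aromatic carbon puts bromo in place of chloro on an aromatic carbon para to a hydroxy group. Among the measured compounds shown here, no measured pair shows a step of this kind. The estimate is a 1.1-fold lower number from compound 1 to compound 3 (0.04 log units; within the scatter) and is expected to stay within the usual scatter. Compound 3 is estimated at 2000 nM with 900 nM to 4500 nM as the expected range.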

Compound 3, half-maximal inhibitory concentration: 2000 nM
Compound 3: the middle estimate sits on the measured number at the digits printed; the measured number falls inside the stated range.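

In this assay, bromo in place of chloro on an aromatic carbon para to a hydroxy group gives a 1.1-fold lower number from compound 1 to compound 3 (0.04 log units; within the scatter). Among these compounds, this is the first single-place comparison, and at this position the assay does not separate the two halogens on the shared core. No data shown bear on why the two readings stay within the scatter. Open, as far as these compounds go, is whether a position so tolerant of this swap would read the same with an amine, a methoxy group or a nitrile there. Also open, from the compounds shown here alone, is whether plain hydrogen there would leave the reading within the scatter.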